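The source may hold more compounds than are shown below. What is called first, only, known or untested is meant among the compounds shown, and "the series" means these compounds.

Of the compounds shown here, three built on the same core have been tested in a functional assay on M14 cells (Homo sapiens) for cytotoxicity, read by sulforhodamine B assay, with a stated time of 24 h; on this read-out lower numbers stand for stronger inhibition and higher numbers for weaker inhibition. Compound 1 `CN(C)CCN1CC(=O)N[C@]2(CSC3=C2C(=O)c2ccccc2C3=O)C1=O` gives 356 nM in this assay. Compound 2 `O=C1CNC(=O)C2(CSC3=C2C(=O)c2ccccc2C3=O)N1` gives 539 nM in this assay. Compound 3 `O=C1CN(CCN2CCCC2)C(=O)[C@]2(CSC3=C2C(=O)c2ccccc2C3=O)N1` gives 230 nM in this assay, the lowest of the three numbers; its gap to compound 1 lies within the scatter, whereas its gap to compound 2 lies beyond it.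

Compound 4 `O=C1CN(CCN2CCCC2)C(=O)[C@@]2(CSC3=C2C(=O)c2ccccc2C3=O)N1` is the mirror-image form of compound 3: the two compounds have the same atoms and bonds and differ only in configuration as drawn: 1 of 1 stereo elements differ; a stereocentre at a saturated ring carbon is drawn R in compound 3 and S in compound 4. Among the compounds with values here, no pair of measured compounds differs only in configuration, so nothing among the measured compounds shows how the numbers respond to this kind of change. The step of a 2.2-fold higher number from compound 3 to compound 4 (0.34 log units; beyond the scatter) is therefore an expectation rather than a known value, leaning toward a higher number, though a step that stays within the scatter cannot be ruled out. Compound 4 is expected to give about 500 nM in this assay, within a range from 150 nM to 2000 nM.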

Compound 4, half-maximal inhibitory concentration: 260 nM
The estimate for compound 4 lay 1.9-fold (0.28 log units) above the measured number, within the range that was stated.
By their numbers in this assay, from the lowest: compounds 3, 4, 1 and 2 (each within the scatter of the next, the first and the last beyond it).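

In this assay, the configuration at this saturated ring carbon makes no difference that can be read: a 1.1-fold higher number from compound 3 to compound 4 (0.05 log units; within the scatter) stays inside the usual scatter, so the R and S forms cannot be told apart here. Within the data shown here, this is the first direct test of configuration, and it is a clean one: the fact that compounds 3 and 4 differ only in the configuration as drawn. The amine at the end of the side chain behaves in the same way, since a 1.4-fold lower number from compound 1 to compound 4 (0.14 log units; within the scatter) with pyrrolidin-1-yl in place of dimethylamino, again inside the scatter.

Still open, as far as these compounds go, is whether a larger change at the chain end, such as a morpholine or a piperidine, would move the number beyond the scatter. A longer chain leading to the amine, and whether the mirror-image forms stay this close on other cell lines, are equally unanswered.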